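The source may report more compounds than this note shows. Statements on the series, on what has been measured and on what is new or still open speak of the compounds shown alone.

Compound 1, `CCN1C/C(=C\c2ccc(OC)c(OC)c2)C(=O)/C(=C/c2ccc(OC)c(OC)c2)C1`, gives 8500 nM in a functional assay on NCI-H1975 cells (Homo sapiens) for cytotoxicity, read by MTT assay, with a stated time of 72 h; a higher number here means a weaker inhibitor, a lower number a stronger inhibitor.
Compound 2, `CCCN1C/C(=C\c2ccc(OC)c(OC)c2)C(=O)/C(=C/c2ccc(OC)c(OC)c2)C1`, gives 11200 nM in this assay.
Compound 3, `COc1cc(/C=C2\CNC/C(=C\c3cc(OC)c(OC)c(OC)c3)C2=O)cc(OC)c1OC`, gives 4000 nM in this assay.

Compound 2 carries the highest of the three numbers in this assay. Its nearest neighbour is compound 1, which lies within the scatter of it, while compound 3, the only one of the three that differs from it in more than one place, sits beyond the scatter at the lower end.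

The change from compound 2 to compound 4, `COc1ccc(/C=C2\CN(C)C/C(=C\c3ccc(OC)c(OC)c3)C2=O)cc1OC`, is hydrogen in place of ethyl on a saturated chain carbon bound to an amine nitrogen in a ring. One measured step speaks to it directly: the step of a 1.3-fold higher number from compound 1 to compound 2 (0.12 log units; within the scatter), which lengthened the chain on the ring nitrogen by one carbon and left the number where it was. Compound 4 shortens that chain in the other direction, past compound 1 to a methyl on the nitrogen. For the measured compounds named here, nothing among the measured compounds suggests that the length of this chain moves the number beyond the scatter, so the step of a 1.4-fold lower number from compound 2 to compound 4 (0.15 log units; within the scatter) in this assay is expected to be small, leaning if anything toward a lower number. Compound 4 is therefore estimated at 8000 nM in this assay, with a range from 3500 nM to 18000 nM.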

Compound 4, half-maximal inhibitory concentration: 6600 nM
For compound 4 the middle estimate is 1.2-fold (0.08 log units) above the measured one, and the stated range covers the measured number.
By their numbers in this assay, from the lowest: compounds 3, 4, 1 and 2 (each within the scatter of the next, the first and the last beyond it).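

With compound 4, the chain at this place can be read as methyl, ethyl and propyl on the same core, and this assay does not separate any of them: a 1.3-fold lower number from compound 1 to compound 4 (0.11 log units; within the scatter), and a 1.7-fold lower number from compound 2 to compound 4 (0.23 log units; within the scatter). The earlier step covered only ethyl to propyl, whereas the full difference, propyl to methyl, now also stays within the scatter, so no order among these three chains can be claimed from these numbers. Nothing available explains why the number holds so steady across this change.

The compounds shown leave open whether this holds beyond small saturated chains, since a butyl chain, a benzyl group or a chain ending in a carboxylic acid at this place could still move the number beyond the scatter. They also leave open whether the same flat response would appear on the core of compound 3, which differs from the other three in more than one place and so cannot be compared with them directly.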